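This account rests on a few compounds, and the source may have more. Where it says the series, first, only, none or still open, it means among the compounds named here.

Compound 1 `COC1=C(C)C(=O)C(CCCCCCCCCCn2cc(C[C@H](O)COCCOC[C@@H](O)Cc3ccc(-c4ccccc4)cc3)nn2)=C(C)C1=O` gives 505 nM in a functional assay on SGC-7901 cells (Homo sapiens) for inhibition, read by MTT assay, with a stated time of 72 h; on this read-out lower numbers stand for stronger inhibition of growth and higher numbers for weaker inhibition of growth. Compound 2 `O[C@H](COCCOC[C@@H](O)Cc1cn(-c2cncnc2)nn1)Cc1ccc(-c2ccccc2)cc1` stands at a limit of this assay, giving > 100000 nM, a result that is a limit rather than a number (the limit of > 100000 nM in this assay, at which 1 of the 2 values shown sits). Compound 3 `O=c1[nH]c2ccc(-n3cc(C[C@H](O)COCCOC[C@@H](O)Cc4ccc(-c5ccccc5)cc4)nn3)cc2s1` differs from compound 2 in one place: a group of 10 heavy atoms (7 carbon, 1 nitrogen, 1 oxygen, 1 sulfur; one five-membered aromatic ring with 2 hetero atoms, one six-membered aromatic ring of carbon only) in place of a group of 6 heavy atoms (4 carbon, 2 nitrogen; one six-membered aromatic ring with 2 hetero atoms), on an aromatic nitrogen, on an aromatic nitrogen. For the measured compounds named here, since compound 2 shows only a limit, no measured pair tells the size of the step to compound 3; a move toward stronger growth inhibition is expected, of uncertain size. Compound 3 is estimated at 30000 nM, between 3000 nM and 100000 nM, an expected step of an at least 3.3-fold lower number from compound 2 to compound 3 (0.52 log units; beyond the scatter).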

Compound 3, concentration for 50% growth inhibition: 10500 nM
Estimate against measurement, compound 3: 2.9-fold (0.46 log units) above; measured number inside the range.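

In this assay, the group on this aromatic nitrogen of the five-membered aromatic ring clearly affects growth inhibition: replacing pyrimidin-5-yl with the two-ring group that carries a hydrogen-bond donor gives an at least 9.5-fold lower number from compound 2 to compound 3 (0.97 log units; beyond the scatter). Compound 2 stands at a limit of this assay, so this step is a bound and its true size stays unknown: the limit of > 100000 nM in this assay, at which 1 of the 3 values shown sits.

The compounds shown leave open whether the hydrogen-bond donor, the sulfur or the larger group as a whole carries this step. They also leave open how a plain phenyl or an aminophenyl group would behave on this nitrogen.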